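Switching the Aryl Group on an Amide-Type Core

The source may report more compounds than this note shows. Statements on the series, on what has been measured and on what is new or still open speak of the compounds shown alone.

Four compounds share a chain carrying a dimethylamino group and a chlorophenyl ring, joined through a carbonyl to an aromatic ring. Compound 1 `Cc1ccccc1C(=O)OC(CCN(C)C)c1ccc(Cl)cc1` and compound 2 `COc1ccc(C(=O)OC(CCN(C)C)c2ccc(Cl)cc2)cc1` are built on one core, compound 3 `Cc1ccccc1C(=O)NC(CCN(C)C)c1ccc(Cl)cc1` and compound 4 `COc1ccc(C(=O)NC(CCN(C)C)c2ccc(Cl)cc2)cc1` on another; the difference between the two cores is not broken down here. In an assay on NIH3T3 cells with Urotensin-2 receptor (Homo sapiens) as the target (a higher number here means that more compound is needed for the effect, a lower number that less compound is needed), compound 1 gives 1700 nM, compound 2 gives 2190 nM and compound 3 gives 3550 nM. Compound 4 has not yet been measured.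

The change from compound 1 to compound 2 is 4-methoxyphenyl in place of 2-methylphenyl on a carbonyl carbon. It made a 1.3-fold higher number from compound 1 to compound 2 (0.11 log units; within the scatter), so the two values are practically indistinguishable. The change from compound 3 to compound 4 is 4-methoxyphenyl in place of 2-methylphenyl on a carbonyl carbon. It is the same kind of change, not the same one: on the first core the carbonyl carbon's other neighbour is an oxygen next to a carbonyl group, on the second it is an amide-type nitrogen. Compound 3 gives the highest of the three numbers, within the scatter of compound 2 and beyond it only against compound 1.

Among the compounds with values here, because the one measured instance of this change gave a 1.3-fold higher number from compound 1 to compound 2 (0.11 log units; within the scatter), the expected step from compound 3 to compound 4 in this assay is similar and small, a 1.2-fold higher number from compound 3 to compound 4 (0.08 log units; within the scatter). This rests on a single pair, so the expected range is kept wide. Compound 4 is therefore estimated at 4300 nM, between 2000 nM and 9500 nM.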

Compound 4, half-maximal effective concentration: 1350 nM
The estimate for compound 4 lay 3.2-fold (0.50 log units) above the measured number; the measured number lies below the stated range.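

In this assay, putting 4-methoxyphenyl in place of 2-methylphenyl on a carbonyl carbon whose other neighbour is an amide-type nitrogen gave a 2.6-fold lower number from compound 3 to compound 4 (0.42 log units; beyond the scatter), a modest step. Set beside the earlier case, the same swap did not behave alike on the two cores: the same change on two cores in this assay, a 1.3-fold higher number (0.11 log units; within the scatter) from compound 1 to compound 2 and a 2.6-fold lower number (0.42 log units; beyond the scatter) from compound 3 to compound 4, 3.4-fold (0.53 log units) apart, beyond the scatter of two such steps. Within the data shown here, this shows that, in this series, the result of the swap on one core is a poor guide to its result on the other, but with only one pair per core it does not show why the two results part, nor whether other swaps would part in the same way.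

Going by these compounds, what stays open is whether this gap is tied to these two aromatic groups or would also appear with others on the same carbonyl carbon, such as a plain phenyl ring or a 2-methoxyphenyl group, which would help show whether the group entering or the group leaving matters more. On these data alone, it is also open whether the gap would survive changes elsewhere in the molecule, for example a longer chain leading to the dimethylamino group, or a primary amine in its place.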